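The source may hold more compounds than are shown below. What is called first, only, known or untested is meant among the compounds shown, and "the series" means these compounds.

Measured so far, in a functional assay on the whole organism (Tail, strain ICR) with Mus musculus as the target, in the tail flick test, with a stated time of 90 min, at a dose of 25 umol/kg by the oral route; on this read-out higher numbers stand for a stronger effect at the one dose given and lower numbers for a weaker effect:

Compound 1, `CC[C@H](C)[C@H](NC(=O)CN(c1nc(Cl)nc2[nH]cnc12)C1CC1)C(=O)O`, gives 27.4%.
Compound 2, `C[C@@H](O)[C@H](NC(=O)CN(c1nc(Cl)nc2[nH]cnc12)C1CC1)C(=O)O`, gives 35.9%.
Compound 3, `CC(C)[C@H](NC(=O)CN(c1nc(Cl)nc2[nH]cnc12)C1CC1)C(=O)O`, gives 30.3%.

All three share one core and differ only in the side chain on the saturated chain carbon bound to an amide-type nitrogen and a carbonyl carbon. Compound 3 stands second of the three numbers, but its neighbours are close on both sides: from compound 1 to compound 3 the change is a number 2.9 percentage points higher from compound 1 to compound 3 (within the scatter), and from compound 2 to compound 3 it is a number 5.6 percentage points lower from compound 2 to compound 3 (within the scatter). The third step, a number 8.5 percentage points higher from compound 1 to compound 2 (within the scatter), also stays within the scatter. So every side-chain exchange seen so far has left the read-out essentially where it was.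

Compound 4, `CC(C)C[C@H](NC(=O)CN(c1nc(Cl)nc2[nH]cnc12)C1CC1)C(=O)O`, is the next member of this series. Its change from compound 3 is isobutyl in place of isopropyl on a saturated chain carbon bound to an amide-type nitrogen and a carbonyl carbon. Since this is one more exchange of a small saturated side chain at the very same place, and since all three measured exchanges of that kind gave no step beyond the scatter, no step beyond the scatter is expected here either; the estimated step is a number 0.7 percentage points higher from compound 3 to compound 4 (within the scatter). Compound 4 is therefore estimated to give 31% in this assay, expected to fall between 20% and 42%.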

Compound 4, a percentage reported as activity, at one dose (the size of the read-out at that dose, not a potency): 27%
Compound 4: middle estimate off by 4 percentage points, on the high side, within the range that was stated.
By their numbers in this assay, from the lowest: compounds 4, 1, 3 and 2 (each within the scatter of the next).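

In this assay, replacing isopropyl with isobutyl on a saturated chain carbon bound to an amide-type nitrogen and a carbonyl carbon gives a number 3.3 percentage points lower from compound 3 to compound 4 (within the scatter) and so shows that going from the smaller to the larger of these saturated side chains leaves the read-out unmoved. Exchanging sec-butyl for isobutyl gives a number 0.4 percentage points lower from compound 1 to compound 4 (within the scatter) and exchanging 1-hydroxyethyl for isobutyl gives a number 8.9 percentage points lower from compound 2 to compound 4 (within the scatter) so the isobutyl side chain also stays level with both of the other groups. Nothing measured here accounts for how flat this position is.

From the compounds shown here alone, it remains open whether a longer chain, a benzyl group, an amine or a carboxylic acid on the side chain would move the read-out beyond the scatter. With only one dose, these numbers also say nothing about potency.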